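This account rests on a few compounds, and the source may have more. Where it says the series, first, only, none or still open, it means among the compounds named here.

The measured compounds:

Compound 1 `N#CC1CC(=O)N(c2cnn3c2CN(C(=O)Nc2cc(F)c(F)c(F)c2)C(C2CC2)C3)C1`. In a toxicity assay on HepG2 2.2.15 cells (Homo sapiens) for cytotoxicity, read by CellTiter-Glo (a higher number here means that more compound is tolerated, a lower number that less compound is tolerated), compound 1 gives > 200000 nM, which is a limit of the assay.
Compound 2 `O=C1OC(c2ccccc2)CN1c1cnn2c1CN(C(=O)Nc1cc(F)c(F)c(F)c1)C(C1CC1)C2`. In this assay compound 2 gives 7410 nM.
Compound 3 `O=C1CC(c2ccccc2)CN1c1cnn2c1CN(C(=O)Nc1cc(F)c(F)c(F)c1)C(Cc1ccccc1)C2`. In this assay compound 3 gives > 2000 nM, also a limit of the assay.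

Compound 1 thus stands at the limit of > 200000 nM in this assay, at which 1 of the 3 values shown sits, with no number beneath it. Compound 4 `O=C1CC(c2ncccn2)CN1c1cnn2c1CN(C(=O)Nc1cc(F)c(F)c(F)c1)C(C1CC1)C2` differs from compound 1 in one place: pyrimidin-2-yl in place of cyano on a saturated ring carbon. For the measured compounds named here, no measured step makes exactly this change. Going by the values given here, the only measured step, an at least 26-fold lower number from compound 1 to compound 2 (1.43 log units; beyond the scatter), puts 2-oxo-5-phenyl-1,3-oxazolidin-3-yl in place of 4-cyano-2-oxopyrrolidin-1-yl and lowers the tolerated amount sharply. Compound 3, carrying a phenyl on a saturated ring carbon of the pyrrolidinone, gives only a limit. A drop is therefore expected for compound 4, though this assay may again report only a limit. Compound 4 is estimated at 30000 nM (range 7000 nM to 200000 nM), an expected step of an at least 6.6-fold lower number from compound 1 to compound 4 (0.82 log units; beyond the scatter).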

Compound 4, half-maximal cytotoxic concentration: > 200000 nM
Compound 4 ended at the assay's limit; the forecaster's own chance of this, stated with the estimate: 40%; at least 6.6-fold (0.82 log units) between middle value and limit.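

In this assay compound 4 gives > 200000 nM, which is a limit of the assay. A pyrimidin-2-yl on this saturated ring carbon thus leaves the reading at the limit also held by compound 1, and the step between the two cannot be read: the limit of > 200000 nM in this assay, at which 2 of the 4 values shown sit. With 2-oxo-4-(pyrimidin-2-yl)pyrrolidin-1-yl in place of 2-oxo-5-phenyl-1,3-oxazolidin-3-yl there is an at least 26-fold higher number from compound 2 to compound 4 (1.43 log units; beyond the scatter), so a six-membered aromatic ring on the five-membered non-aromatic ring does not by itself lower the tolerated amount. Open, as far as these compounds go, is whether phenyl at this carbon, with the rest of compound 4 unchanged, would lower the number. Also open, from the compounds shown here alone, is whether an amine or a carboxylic acid there would stay at the limit.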